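Swapping one side chain on a shared core

The source may hold more compounds than are shown below. What is called first, only, known or untested is meant among the compounds shown, and "the series" means these compounds.

Results in an ADME assay on BaF3 cells (Mus musculus) for antiproliferative activity, read by CCK-8 assay, with a stated time of 72 h (a lower number here means a stronger inhibitor of growth, a higher number a weaker inhibitor of growth), for the measured compounds
compound 1 `O=C(CCSc1ccc2c(/C=C/c3ccccn3)n[nH]c2c1)Nc1cccc(C(F)(F)F)c1` gives 2300 nM
compound 2 `O=C(CCSc1ccc2c(/C=C/c3ccccn3)n[nH]c2c1)Nc1ccc(Cl)c(C(F)(F)F)c1` gives > 10000 nM as a limit of the assay and not a number
compound 3 `CN(C)CCN(C)Cc1ccc(NC(=O)CCSc2ccc3c(/C=C/c4ccccn4)n[nH]c3c2)cc1C(F)(F)F` gives 1850 nM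

Compound 3 at 1850 nM sits within the scatter of compound 1 at 2300 nM and the two cannot be told apart here. Compound 4 `O=C(CCSc1ccc2c(/C=C/c3ccccn3)n[nH]c2c1)Nc1ccc(CN2CCCC2)c(C(F)(F)F)c1` keeps the shared core and changes one group: pyrrolidin-1-yl in place of (2-(dimethylamino)ethyl)(methyl)amino on a saturated chain carbon bound to an aromatic carbon with pyrrolidin-1-yl in place of (2-(dimethylamino)ethyl)(methyl)amino on a saturated chain carbon bound to an aromatic carbon.

Within the data shown here, three measured steps bear on this change, none of them directly. Setting the whole ((2-(dimethylamino)ethyl)(methyl)amino)methyl group in place of hydrogen gave a 1.2-fold lower number from compound 1 to compound 3 (0.09 log units; within the scatter) and stayed within the scatter. Chloro in place of hydrogen gave an at least 4.3-fold higher number from compound 1 to compound 2 (0.63 log units; beyond the scatter) and the same group in place of chloro gave an at least 5.4-fold lower number from compound 2 to compound 3 (0.73 log units; beyond the scatter) and both lie beyond the scatter. Both of these rest on a limit and involve chloro, which compound 4 does not carry. Among the measured compounds shown here, no measured step alters the amino part of the group itself.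

A change beyond the scatter in this assay is therefore not expected, and the estimated step is a 1.1-fold higher number from compound 3 to compound 4 (0.03 log units; within the scatter) in size. For compound 4 the estimate is 2000 nM with an expected range from 700 nM to 6000 nM for now.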

Compound 4, concentration for 50% growth inhibition: 4000 nM
For compound 4 the middle estimate is 2.0-fold (0.30 log units) below the measured one, and the stated range covers the measured number.
By their numbers in this assay, from the lowest: compounds 3, 1 and 4 (each within the scatter of the next, the first and the last beyond it). At a limit, above all of these: compound 2.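

Among these compounds, the amino part of the side chain had not been varied in the earlier compounds, and this pair shows that it can shift the result on its own: in this assay, pyrrolidin-1-yl in place of (2-(dimethylamino)ethyl)(methyl)amino gives a 2.2-fold higher number from compound 3 to compound 4 (0.33 log units; beyond the scatter), a modest step. Compared with hydrogen at the same aromatic carbon, (pyrrolidin-1-yl)methyl gives a 1.7-fold higher number from compound 1 to compound 4 (0.24 log units; within the scatter), so this group, like the longer one in compound 3, brings no gain over compound 1 that can be told from the scatter. Compared with chloro, the same group gives an at least 2.5-fold lower number from compound 2 to compound 4 (0.39 log units; beyond the scatter), but the value of compound 2 is a limit of the assay and not a number, so this step has only a lower bound: the limit of > 10000 nM in this assay, at which 1 of the 4 values shown sits.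

A single pair cannot separate the effect of closing the ring from that of losing the second nitrogen and the shorter size of the group. Piperidine, morpholine or a simple dimethylamino group on the same saturated chain carbon would show whether the step follows the ring, its size or the number of amine nitrogens.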